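Oxy chains on the aromatic nitrogen: carbamoylmethoxy to 2-carboxyethoxy

The source may report more compounds than this note shows. Statements on the series, on what has been measured and on what is new or still open speak of the compounds shown alone.

Measured in a functional assay on a cell-free system (plasma, Oryctolagus cuniculus) for inhibition, with stated times of 5 min, 1 min and 6 min; a higher number here means a weaker inhibitor, a lower number a stronger inhibitor:
- compound 1 `CCOC(=O)c1[nH]c(-c2cccc(C#N)c2)nc1C`: > 30000 nM (a limit)
- compound 2 `CCOC(=O)c1c(C)nc(-c2cccc(C#N)c2)n1OCCCO`: 11400 nM
- compound 3 `CCOC(=O)c1c(C)nc(-c2cccc(C#N)c2)n1OCC(N)=O`: > 30000 nM (a limit)

Compound 3 stands at > 30000 nM, which is a limit of the assay and not a number. The series is bounded by the limit of > 30000 nM in this assay, at which 2 of the 3 values shown sit.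

The next compound is compound 4 `CCOC(=O)c1c(C)nc(-c2cccc(C#N)c2)n1OCCC(=O)O`, in which carboxymethyl replaces carbamoyl on a saturated chain carbon bound to an oxygen on an aromatic ring (carboxymethyl in place of carbamoyl on a saturated chain carbon bound to an oxygen on an aromatic ring). Cut one bond further out, the same difference reads carbamoylmethoxy to 2-carboxyethoxy.

Within the data shown here, three measured steps bear on this change. Exchange at the same carbon gave an at least 2.6-fold higher number from compound 2 to compound 3 (0.42 log units; beyond the scatter). Placing 3-hydroxypropoxy on the aromatic nitrogen gave an at least 2.6-fold lower number from compound 1 to compound 2 (0.42 log units; beyond the scatter), whereas carbamoylmethoxy gave a step that the two limits leave unreadable from compound 1 to compound 3. Among the measured compounds shown here, only compound 2 gives a number, 11400 nM, and it remains the sole guide to how far such a chain can move the read-out.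

With no acid yet measured, no step beyond the scatter is expected in this assay, and a reading at the limit is quite possible. The expected change is an at least 1.2-fold lower number from compound 3 to compound 4 (0.07 log units; that floor lies within the scatter). For compound 4 the estimated value is 25000 nM, with an expected range of 9000 nM to 60000 nM.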

Compound 4, half-maximal inhibitory concentration: > 30000 nM
Compound 4: a limit, no number; the forecaster's own chance of this, stated with the estimate: 55%; middle value at least 1.2-fold (0.07 log units) from the limit.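

In this assay, the 2-carboxyethoxy chain of compound 4 also ends at a limit of the assay, as do the carbamoylmethoxy chain of compound 3 and the hydrogen on the aromatic nitrogen of compound 1, so the 3-hydroxypropoxy chain of compound 2 remains the only group shown at this position that gives a number. The new readable result is that carboxy in place of hydroxymethyl gives an at least 2.6-fold higher number from compound 2 to compound 4 (0.42 log units; beyond the scatter), which makes compound 2 the one exception among the four compounds and shows that keeping the chain on the aromatic nitrogen does not by itself preserve a measurable value. The steps from compound 3 to compound 4 and from compound 1 to compound 4 cannot be read, and the series stays bounded by a single limit: the limit of > 30000 nM in this assay, at which 3 of the 4 values shown sit.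

On these data alone, how far compound 3 and compound 4 lie past the limit stays open, so the carbamoyl and carboxymethyl groups cannot be ranked against each other. Also open, as far as these compounds go, is whether a 3-aminopropoxy or a 4-hydroxybutoxy chain on the aromatic nitrogen would give a number, and how that number would compare with compound 2.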